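A few compounds are considered here, and "the series" means these few. Any claim that something is new, unique, unknown or untested is made for them only; others in the source may bear on it.

Compound 1, `Cc1ccc(CO/N=C/c2c(C)nn(C)c2Oc2ccc(Cl)cc2)cc1`: 50%
Compound 2, `Cc1nn(C)c(Oc2ccc(Cl)cc2)c1/C=N/OCc1ccc(C(F)(F)F)cc1`: 50.9%

In a functional assay on A549 cells (Homo sapiens) for antiproliferative activity, tested at 1 uM (a higher number here means more inhibition at the concentration tested (going by the name of the read-out), a lower number less inhibition), compound 2 gives 50.9%, and compound 1 gives 50%. The step of a number 0.9 percentage points higher from compound 1 to compound 2 (within the scatter) lies within the scatter, so the two compounds stand level in this assay; neither number can be called the higher of the pair.

Compound 3, `COC(=O)c1ccc(CO/N=C/c2c(C)nn(C)c2Oc2ccc(Cl)cc2)cc1`, is not yet measured. It differs from compound 2 in one place: methoxycarbonyl in place of trifluoromethyl on an aromatic carbon. For the measured compounds named here, the only measured step that touches this position is the one from compound 1 to compound 2, where trifluoromethyl replaced methyl on the same aromatic carbon and the number moved by a number 0.9 percentage points higher from compound 1 to compound 2 (within the scatter), a change that stayed within the scatter. That step shows that two different groups at this position gave the same read-out in this assay, but nothing is known about methoxycarbonyl there.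

On this basis compound 3 is expected to behave like compound 2 in this assay, with an estimated step of a number 0.9 percentage points lower from compound 2 to compound 3 (within the scatter), which is no change beyond the scatter. The estimate for compound 3 is therefore 50%, with a range from 35% to 65%.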

Compound 3, a percentage reported as inhibition, at one concentration (the size of the read-out at that concentration, not a potency): 49.9%
Beside the measured number, compound 3's estimate is 0.1 percentage points above it, within the range that was stated.
By their numbers in this assay, from the lowest: compounds 3, 1 and 2 (each within the scatter of the next).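

Methoxycarbonyl, on an aromatic carbon para to a large group, brings to this position 2 hydrogen-bond acceptors and 1 double bond outside aromatic rings, neither of which trifluoromethyl has. Even with that difference, this assay gives a step of a number 1 percentage points lower from compound 2 to compound 3 (within the scatter), and the comparison with the methyl compound gives a step of a number 0.1 percentage points lower from compound 1 to compound 3 (within the scatter), so all three groups now stand level at this position, where the earlier compounds offered only two groups without any hydrogen-bond acceptor. Nothing available explains why these three groups read alike.

The compounds shown leave open whether this level reading would extend to groups of another kind at the same carbon, such as an amine, a carboxylic acid or a longer chain, since all three groups seen so far are small and uncharged. They also leave open whether the three compounds would still stand level at other concentrations, because this read-out is taken at a single concentration and gives the size of the inhibition there, not a potency.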